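A few compounds are considered here, and "the series" means these few. Any claim that something is new, unique, unknown or untested is made for them only; others in the source may bear on it.

Measured so far in a functional assay on CHO cells for agonist activity at adenosine receptor A1 (Homo sapiens), read by fluorescence and ERK phosphorylation, with stated times of 30 min and 1.5 h, tested at 10 uM; on this read-out higher numbers stand for a stronger effect at the one concentration tested and lower numbers for a weaker effect:
compound 1 `Nc1scc(-c2cccc(F)c2)c1C(=O)c1ccccc1` gives 52%;
compound 2 `Nc1scc(-c2cccc(C(F)(F)F)c2)c1C(=O)c1ccc(Cl)cc1` gives 73%;
compound 3 `Nc1scc(-c2cccc(F)c2)c1C(=O)c1ccc(Cl)cc1` gives 90%.

Compound 3 stands highest of the three numbers, with compound 2 nearest and compound 1 furthest, both gaps beyond the scatter. The steps seen are a number 38 percentage points higher from compound 1 to compound 3 (beyond the scatter) and a number 17 percentage points higher from compound 2 to compound 3 (beyond the scatter).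

Compound 4 `Nc1scc(-c2ccc(Br)cc2)c1C(=O)c1ccc(Cl)cc1` differs from compound 3 by 4-bromophenyl in place of 3-fluorophenyl on an aromatic carbon. Within the data shown here, no measured step matches this change; only the step from compound 2 to compound 3 touches the same aryl group, and it was modest. A modest drop or no change beyond the scatter is therefore expected in this assay, a number 15 percentage points lower from compound 3 to compound 4 (beyond the scatter). Compound 4 is estimated at 75%, between 50% and 95%.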

Compound 4, a percentage reported as activity, at one concentration (the size of the read-out at that concentration, not a potency): 46%
Estimate against measurement, compound 4: 29 percentage points above; the measured number lies below the stated range.
By their numbers in this assay, from the lowest: compounds 4 and 1 (each within the scatter of the next); then compound 2; then compound 3.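

In this assay, among these compounds, the aryl group on this aromatic carbon matters more than the earlier compounds showed: 4-bromophenyl in place of 3-fluorophenyl gives a number 44 percentage points lower from compound 3 to compound 4 (beyond the scatter), a large step, against the modest a number 17 percentage points higher from compound 2 to compound 3 (beyond the scatter). This change swaps the halogen and moves it on the phenyl ring, so the step cannot be assigned to either alone. No measurement at hand explains the step. Open, from the compounds shown here alone, is whether the fall follows the bromine or its place on the phenyl ring. Also open, going by these compounds, is how an amine or a methoxy group would behave in place of the halogen.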